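The source may report more compounds than this note shows. Statements on the series, on what has been measured and on what is new or still open speak of the compounds shown alone.

Compound 1, `CCCCCCCc1nc(N)n(CC(=O)Nc2ccccc2)c1-c1ccccc1Br`, gives 9200 nM in a functional assay on A-375 cells (Homo sapiens) for antiproliferative activity, read by MTT assay, with a stated time of 48 h; a higher number here means a weaker inhibitor, a lower number a stronger inhibitor. Compound 2, `Nc1nc(CC2CC2)c(-c2ccccc2Br)n1CC(=O)Nc1ccccc1`, gives 5800 nM in this assay.

Compound 2 stands at the low end of the two numbers shown, yet its only neighbour, compound 1, sits within the scatter, as a 1.6-fold lower number from compound 1 to compound 2 (0.20 log units; within the scatter) shows, so no order between them holds. Compound 3, `COc1ccc(Cc2nc(N)n(CC(=O)Nc3ccccc3)c2-c2ccccc2Br)cc1`, differs from compound 2 by 4-methoxyphenyl in place of cyclopropyl on a saturated chain carbon bound to an aromatic carbon. Within the data shown here, the one measured step swaps one saturated group for another and bears only loosely on an aromatic ring entering; it was within the scatter. No step beyond the scatter is therefore expected in this assay. Compound 3 is estimated at 4500 nM (range 1500 nM to 14000 nM), an expected step of a 1.3-fold lower number from compound 2 to compound 3 (0.11 log units; within the scatter).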

Compound 3, half-maximal inhibitory concentration: 1400 nM
Compound 3: middle estimate off by 3.2-fold (0.51 log units), on the high side; the whole stated range lies above it.
By their numbers in this assay, from the lowest: compound 3; then compounds 2 and 1 (each within the scatter of the next).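

On the saturated chain carbon bound to an aromatic carbon, the choice of group now registers in this assay: 4-methoxyphenyl in place of cyclopropyl gives a 4.1-fold lower number from compound 2 to compound 3 (0.62 log units; beyond the scatter) and 4-methoxyphenyl in place of hexyl gives a 6.6-fold lower number from compound 1 to compound 3 (0.82 log units; beyond the scatter) while the exchange between the two saturated groups had stayed within the scatter. Nothing available accounts for this difference. On these data alone, whether the aromatic ring itself or its methoxy substituent matters remains open. Plain phenyl, 4-fluorophenyl or a chain ending in an amine at this place would test that.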